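The compounds below may be only part of what the source reports. "The series", "measured", "known", "first", "only" and "open" are said of these compounds alone.

Measured so far:
compound 1 `CCCCCCCCCCCCCCCCc1c(C)c(N(C)C)nc(C)c1O` — 83%
compound 2 `CCCCCCCCCCCCCCCCc1c(C)c(N2CCC2)nc(C)c1O` — 72%

In a functional assay on cells (Lymphocyte, Homo sapiens) for inhibition, read by flow cytometry, using a membrane potential dye, with a stated time of 16 h, tested at 250 nM (on this read-out lower numbers stand for a weaker effect and higher numbers for a stronger effect at the one concentration tested), compound 1 gives 83%, the highest of the two numbers. For the measured compounds named here, the only measured step, a number 11 percentage points lower from compound 1 to compound 2 (beyond the scatter), changes the amine on the core and says nothing about the chain. Compound 3 `CCCCCCCCCCCCCCCCCCCc1c(C)c(N(C)C)nc(C)c1O` differs from compound 1 by propyl in place of hydrogen on a saturated chain carbon, ten or more bonds along the chain from an aromatic carbon. Going by the values given here, no measured pair tests a change of chain length, so nothing here predicts a shift; the working expectation is no step beyond the scatter, a number 3 percentage points lower from compound 1 to compound 3 (within the scatter). Compound 3 is therefore estimated at 80%, with a range from 60% to 95%.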

Compound 3, a percentage reported as activity, at one concentration (the size of the read-out at that concentration, not a potency): 42%
Estimate against measurement, compound 3: 38 percentage points above; measured number outside the range, below it.
By their numbers in this assay, from the lowest: compound 3; then compound 2; then compound 1.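

In this assay the chain is not a silent position: propyl in place of hydrogen on a saturated chain carbon, ten or more bonds along the chain from an aromatic carbon, gives a number 41 percentage points lower from compound 1 to compound 3 (beyond the scatter) and so a large step, where a number 11 percentage points lower from compound 1 to compound 2 (beyond the scatter) at the amine was modest. This read-out therefore responds to chain length and not only to the amine on the core. Nothing available bears on the reason for this step.

Open, going by these compounds, is whether a shorter chain such as dodecyl raises the number or leaves it unchanged. Also open, on these data alone, is whether the step from the longer chain holds with azetidin-1-yl as the amine.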